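This account rests on a few compounds, and the source may have more. Where it says the series, first, only, none or still open, it means among the compounds named here.

Measured so far in a functional assay on A549 cells (Homo sapiens) for cytotoxicity, read by MTT assay, with a stated time of 48 h; a lower number here means a stronger inhibitor, a higher number a weaker inhibitor:

- Compound 1 `COc1c(OCc2cnoc2C)cc(O)c2c(=O)cc(-c3ccccc3)oc12`: > 100000 nM (a limit)
- Compound 2 `COc1c(OCc2ncc(C)o2)cc(O)c2c(=O)cc(-c3ccccc3)oc12`: > 100000 nM (a limit)
- Compound 3 `COc1c(OCCCCN2CCCC2)cc(O)c2c(=O)cc(-c3ccccc3)oc12`: 1530 nM

Among the compounds with values here, compound 3 holds the only number; the other two entries mark the limit of > 100000 nM in this assay, at which 2 of the 3 values shown sit, and nothing more. Compound 4 `COc1c(OCCCNCc2ccccc2)cc(O)c2c(=O)cc(-c3ccccc3)oc12` differs by benzylamino in place of (pyrrolidin-1-yl)methyl on a saturated chain carbon, three bonds along the chain from an oxygen on an aromatic ring. The steps bearing on this are an at least 65-fold lower number from compound 1 to compound 3 (1.81 log units; beyond the scatter) and an at least 65-fold lower number from compound 2 to compound 3 (1.81 log units; beyond the scatter), both large, and both bring in 3-(pyrrolidin-1-yl)propyl. The third, a step that the two limits leave unreadable from compound 1 to compound 2, gives no size. Neither large step alters the end of a chain already carrying nitrogen. Compound 4 keeps a nitrogen on the chain, as compound 3 does at 1530 nM, so only a moderate move towards a higher number is expected in this assay here. The estimated change is a 2.6-fold higher number from compound 3 to compound 4 (0.42 log units; beyond the scatter) and remains an expectation. Expected for compound 4 is 4000 nM with an estimated range from 1200 nM to 18000 nM in this series.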

Compound 4, half-maximal inhibitory concentration: 1570 nM
Estimate against measurement, compound 4: 2.5-fold (0.41 log units) above, within the range that was stated.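

In this assay, benzylamino replaces (pyrrolidin-1-yl)methyl on the saturated chain carbon with a 1.0-fold higher number from compound 3 to compound 4 (0.01 log units; within the scatter), so at this place the ring amine and the open benzylamino group cannot be told apart. The large steps now recur with a second nitrogen-bearing chain, an at least 63-fold lower number from compound 1 to compound 4 (1.80 log units; beyond the scatter) and an at least 63-fold lower number from compound 2 to compound 4 (1.80 log units; beyond the scatter). Both rest on limits, not numbers, for compound 1 and compound 2: the limit of > 100000 nM in this assay, at which 2 of the 4 values shown sit.

Open, from the compounds shown here alone, is what a chain ending in a hydroxyl group or an amide would give in place of the amine. Also open, going by these compounds, is a longer chain carrying the same amine.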